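This account rests on a few compounds, and the source may have more. Where it says the series, first, only, none or still open, it means among the compounds named here.

This small set of compounds shares one core and was tested in a functional assay on MDA-MB cells (Homo sapiens) for cytotoxicity, read by MTT assay, with a stated time of 48 h; a lower number here means a stronger inhibitor, a higher number a weaker inhibitor. Only one of the three measured compounds gives a number: compound 1 (`CCCCC1C(C(=O)OCC)=C(C)NC(C)=C1C(=O)OCC`) comes in at 350000 nM. The starting point here, compound 2 (`CCCC1C(C(=O)OC)=C(C)NC(C)=C1C(=O)OC`), is recorded as "not active" (no number reported), so it has no single value to place on a scale. The same entry stands for compound 3 (`CCCCC1C(C(=O)OC)=C(C)NC(C)=C1C(=O)OC`), which reads "not active" (no number reported). For the measured compounds named here, the only number available is therefore a high one, which marks weak inhibition, and the other two compounds give no number at all.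

The next compound to be tested is compound 4 (`COC(=O)C1=C(C)NC(C)=C(C(=O)OC)C1c1ccc(OC)cc1`). The change is 4-methoxyphenyl in place of propyl on a saturated ring carbon. Put simply, it is 4-methoxyphenyl in place of propyl on a saturated ring carbon, so an aromatic ring enters where an open chain stood.

Going by the values given here, no measured pair in this set shows what such a swap does, so any forecast is uncertain. A modest step towards lower numbers in this assay is expected, and it may well not be enough to produce a reportable value. If a number does appear, it should lie in the same weak region as compound 1 at 350000 nM. For compound 4 the estimated value is 200000 nM, with an expected range of 50000 nM to 600000 nM.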

Compound 4, half-maximal inhibitory concentration: "not active" (no number reported)
Compound 4 has no reported number here, and the estimate cannot be compared.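

Compound 4 and compound 2 are both recorded as "not active" with no number in this assay, so no step can be read between them. Nothing measured here accounts for this result. The compounds shown leave open whether 4-methoxyphenyl in place of propyl changes cytotoxicity at all, and by how much.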